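A few compounds are considered here, and "the series" means these few. Any claim that something is new, unique, unknown or untested is made for them only; others in the source may bear on it.

Measured so far in a functional assay on HeLa cells (Homo sapiens) for cytotoxicity, read by MTT assay, with a stated time of 48 h; on this read-out higher numbers stand for weaker inhibition and lower numbers for stronger inhibition:

compound 1 `C=C1CO[C@]2(CO[C@@H]3O[C@H](CO[C@@H]4OC[C@](O)(CO)[C@H]4O)[C@@H](O)[C@H](O)[C@H]3O)C(C)=CC[C@H]12` gives > 50000 nM, a limit of the assay and not a number.
compound 2 `C[C@H]1C(=O)OC[C@H]2[C@@H]1CC[C@@]2(C)O` gives > 50000 nM, likewise a limit of the assay.
compound 3 `C=C(CO)[C@H]1C[C@H](OC(=O)CC(C)C)[C@@](C)(O)[C@H]1CO[C@@H]1O[C@H](CO)[C@@H](O)[C@H](O)[C@H]1O` gives > 50000 nM, likewise a limit of the assay.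

Where compound 1 stands cannot be ranked against the others: only a limit is recorded for it, and the same holds for compound 2 and compound 3, so the limit of > 50000 nM in this assay, at which 3 of the 3 values shown sit, is the whole of what the numbers say. For the measured compounds named here, no pair of measured compounds differs in a single place, and so no measured step exists to show a direction or a size.

Compound 4 `C=C1CO[C@]2(CO[C@@H]3O[C@H](CO)[C@@H](O)[C@H](O)[C@H]3O)C(C)=CC[C@H]12` has not yet been measured in this assay. It differs from compound 1 as follows: hydrogen in place of 3,4-dihydroxy-4-(hydroxymethyl)oxolan-2-yl on an oxygen on a saturated carbon. The shared core of compound 1 and compound 4 stays untouched.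

With every recorded value sitting at the limit, nothing in the series points to any step in either direction; the expectation is that a step that the limit leaves unreadable from compound 1 to compound 4 amounts to no change beyond the scatter, most probably with the assay again reporting only a limit. Compound 4 is therefore estimated at 60000 nM, within a range from 20000 nM to 200000 nM.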

Compound 4, half-maximal inhibitory concentration: > 50000 nM
Compound 4: only a limit was reported (the forecaster's own chance of this, stated with the estimate: 85%); the middle value is on the limit's open side.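

Compound 1 and compound 4 both report only a limit of the assay in this assay, so no step between them can be read: the limit of > 50000 nM in this assay, at which 4 of the 4 values shown sit.

The compounds shown leave open whether the 3,4-dihydroxy-4-(hydroxymethyl)oxolan-2-yl group matters at all, as none of them gives a number in this assay.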